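This account rests on a few compounds, and the source may have more. Where it says the series, first, only, none or still open, it means among the compounds named here.

Measured compounds:
compound 1 `CCC(C)n1cnc2c(NCc3ccc(C(=O)Nc4ccccc4N)cc3)nc(Cl)nc21`: 75.1%
compound 2 `Nc1ccccc1NC(=O)c1ccc(Cn2cnc3c(NCc4ccccc4)nc(Cl)nc32)cc1`: 78.4%
compound 3 `Nc1ccccc1NC(=O)c1ccc(COCNc2nc(Nc3ccccc3)c3ncn(C4CCCC4)c3n2)cc1`: 76.9%

In a functional assay on HCT-116 cells (Homo sapiens) for antiproliferative activity, read by CCK-8 assay, with a stated time of 72 h, tested at 8 uM (a lower number here means a weaker effect, a higher number a stronger effect of the compound at the concentration tested), compound 2 gives 78.4%, the highest of the three numbers, yet compound 3 with 76.9% and compound 1 with 75.1% both lie within the usual scatter of it, so the three are not separated. Compound 4 `Nc1ccccc1NC(=O)c1ccc(Cn2cnc3c(Nc4cccc(OC(F)(F)F)c4)nc(Cl)nc32)cc1` has not been measured. It differs from compound 2 by 3-(trifluoromethoxy)phenyl in place of benzyl on a nitrogen on an aromatic ring. Among the measured compounds shown here, no measured pair shows the effect of such a change, and the three known values give no trend to lean on. The step of a number 6.4 percentage points lower from compound 2 to compound 4 (within the scatter) is therefore expected to stay within the scatter, in no particular direction. Compound 4 is expected to give about 72%, with a range from 52% to 86%.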

Compound 4, a percentage reported as inhibition, at one concentration (the size of the read-out at that concentration, not a potency): 46.6%
For compound 4 the middle estimate is 25.4 percentage points above the measured one, outside the stated range (below it).
By their numbers in this assay, from the lowest: compound 4; then compounds 1, 3 and 2 (each within the scatter of the next).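

In this assay, replacing benzylamino with (3-(trifluoromethoxy)phenyl)amino gives a number 31.8 percentage points lower from compound 2 to compound 4 (beyond the scatter). Among the compounds shown here, this is the first step between compounds differing in one place, and it shows that the group on this nitrogen can change the read-out substantially, which compounds 1, 2 and 3 could not show. Nothing shown here explains the drop. As far as these compounds go, it remains open whether the loss goes with the trifluoromethoxy group or with the change from benzyl to an aryl group attached directly; a plain phenyl group on the same nitrogen of the core of compound 2 would separate the two.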